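This account rests on a few compounds, and the source may have more. Where it says the series, first, only, none or still open, it means among the compounds named here.

Compound 1 `CC1=C(C(=O)Nc2ccc(Br)cc2)C(c2ccccc2)NC(=O)N1` was examined in an ADME assay on Vero cells (Chlorocebus sabaeus) for cytotoxicity, read by XTT assay, with a stated time of 72 h; on this read-out lower numbers stand for higher toxicity in this test and higher numbers for lower toxicity in this test. In this assay compound 1 gives > 100000 nM, which is a limit of the assay and not a number. Compound 2 `CC1=C(C(=O)Nc2ccc(F)cc2)C(c2ccccc2)NC(=O)N1` gives in this assay > 100000 nM, again a limit rather than a number. Compound 3 `CC1=C(C(=O)NC2CCCCC2)C(c2ccccc2)NC(=O)N1` gives in this assay > 100000 nM, which is also a limit. Compound 3 therefore stands at the limit of the test, and the two further values shown are limits as well. The measured steps, a step that the two limits leave unreadable from compound 1 to compound 2, a step that the two limits leave unreadable from compound 1 to compound 3 and a step that the two limits leave unreadable from compound 2 to compound 3, cannot be sized because of the limit of > 100000 nM in this assay, at which 3 of the 3 values shown sit. Compound 4 `CC1=C(C(=O)Oc2ccccc2)C(c2ccccc2)NC(=O)N1` differs from compound 3 by phenoxy in place of cyclohexylamino on a carbonyl carbon. None of the measured steps bears readably on this change, so no step beyond the scatter can be expected from the numbers shown. The step of a number no higher from compound 3 to compound 4 (the limit leaves the size open) is therefore the estimate. Compound 4 is expected to give about 100000 nM in this assay, within 40000 nM to 300000 nM, most likely reported only as a limit.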

Compound 4, half-maximal cytotoxic concentration: > 100000 nM
Compound 4: only a limit was reported (the forecaster's own chance of this, stated with the estimate: 80%); the middle value lies on the limit itself.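

Compound 4 cannot be compared with compound 1, compound 2 or compound 3 in this assay, because no step to it can be read: the limit of > 100000 nM in this assay, at which 4 of the 4 values shown sit.

The compounds shown leave open how far these four differ in cytotoxicity, and which change to the shared core, if any, would give a readable value.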